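Nitroimidazole oxadiazole series: from chlorophenyl to aminopyridinyl

A few compounds are considered here, and "the series" means these few. Any claim that something is new, unique, unknown or untested is made for them only; others in the source may bear on it.

In a functional assay on MCF7 cells (Homo sapiens) for cytotoxicity, read by MTT assay, with a stated time of 48 h (a lower number here means a stronger inhibitor, a higher number a weaker inhibitor), the three measured compounds stand as follows:
- compound 1, `CCOc1ccc(-c2nnc(SCCn3c([N+](=O)[O-])cnc3C)o2)cc1`: 16600 nM
- compound 2, `Cc1ncc([N+](=O)[O-])n1CCSc1nnc(-c2ccc(Cl)cc2)o1`: 18700 nM
- compound 3, `Cc1ncc([N+](=O)[O-])n1CCSc1nnc(-c2ccc(N(C)C)cc2)o1`: 14900 nM

Compound 2 carries the highest of the three numbers, but its nearest neighbour is compound 1 with a 1.1-fold higher number from compound 1 to compound 2 (0.05 log units; within the scatter), and the furthest is compound 3 with a 1.3-fold lower number from compound 2 to compound 3 (0.10 log units; within the scatter); neither gap is beyond the scatter, so the three compounds are indistinguishable on these data. The third pair behaves the same way, with a 1.1-fold lower number from compound 1 to compound 3 (0.05 log units; within the scatter).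

Compound 4, `Cc1ncc([N+](=O)[O-])n1CCSc1nnc(-c2ccc(N)nc2)o1`, is not yet measured. It differs from compound 2 as follows: 6-aminopyridin-3-yl in place of 4-chlorophenyl on an aromatic carbon.

All three measured steps exchange one group on the same aromatic carbon and none moves the number beyond the scatter. The step to compound 4 is of a different kind: the whole ring changes, bringing in a ring hetero atom and an amino group with one hydrogen-bond donor and two acceptors. Among the compounds with values here, no measured step covers such a change, so the only guide is that the shared core has so far tolerated variation at this position without a shift in this assay.

For compound 4 the expectation is therefore a number close to that of compound 2, with widened uncertainty, estimated as 17000 nM with a range of 7000 nM to 42000 nM. The estimated step is a 1.1-fold lower number from compound 2 to compound 4 (0.04 log units; within the scatter), which is expected to stay within the scatter.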

Compound 4, half-maximal inhibitory concentration: 26800 nM
Compound 4: the middle estimate sits 1.6-fold (0.20 log units) below what was measured; the measured number falls inside the stated range.
By their numbers in this assay, from the lowest: compounds 3, 1, 2 and 4 (each within the scatter of the next).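

In this assay, exchanging the whole ring at this position gives a 1.4-fold higher number from compound 2 to compound 4 (0.16 log units; within the scatter) and stays within the scatter, so tolerance here now extends beyond swaps of a single group on the same aromatic carbon to 6-aminopyridin-3-yl in place of 4-chlorophenyl. Within the data shown here, the entering group brings a ring hetero atom, an amino group and hydrogen-bond donor and acceptor atoms that the leaving group lacks, yet this step cannot be told apart from the earlier steps, all of which also lie within the scatter. Nothing available ties the size of this step to any property of the new ring.

The ring nitrogen and the amino group enter together, so the compounds shown cannot separate their contributions; a 4-aminophenyl or an unsubstituted pyridin-3-yl group at this position would divide the change into single steps. Also open, from the compounds shown here alone, is whether the same tolerance holds for a carboxylic acid on the aromatic ring, for a saturated ring such as piperidine in its place, or for a longer chain linking the two halves of the shared core.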